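A few compounds are considered here, and "the series" means these few. Any claim that something is new, unique, unknown or untested is made for them only; others in the source may bear on it.

In a functional assay on MOLT-4 cells (Homo sapiens) for cytotoxicity, read by CCK-8 assay, with a stated time of 24 h (on this read-out lower numbers stand for stronger inhibition and higher numbers for weaker inhibition), the values so far are these:

Compound 1 `C=CC(=O)N1C(=O)CC(c2ccc(C)cc2)Sc2ccccc21` gives 87600 nM
Compound 2 `C=CC(=O)N1C(=O)CC(c2ccc(Cl)cc2)Sc2ccccc21` gives 82400 nM
Compound 3 `C=CC(=O)N1C(=O)CC(c2ccc([N+](=O)[O-])cc2)Sc2ccccc21` gives 91500 nM

Compound 3 stands level with the other two (a 1.0-fold higher number from compound 1 to compound 3 (0.02 log units; within the scatter) and a 1.1-fold higher number from compound 2 to compound 3 (0.05 log units; within the scatter)). The next structure, compound 4 `C=CC(=O)N1C(=O)CC(c2ccc(C(=O)OC)cc2)Sc2ccccc21`, has methoxycarbonyl in place of nitro on an aromatic carbon, para to a large group (methoxycarbonyl in place of nitro on an aromatic carbon). The remaining measured step (a 1.1-fold lower number from compound 1 to compound 2 (0.03 log units; within the scatter)) is of the same size, so methyl, chloro and nitro at this place are not told apart by the read-out. For the measured compounds named here, no measured compound carries methoxycarbonyl, so the expectation is an extrapolation from these three. Taking compound 3 at 91500 nM as the anchor, no step beyond the scatter is expected in this assay for this change, and no direction can be assigned. The estimated step is small (a 1.0-fold lower number from compound 3 to compound 4 (0.02 log units; within the scatter)). The expected value for compound 4 is 88000 nM (expected range 58000 nM to 130000 nM).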

Compound 4, half-maximal inhibitory concentration: 79600 nM
Compound 4: middle estimate off by 1.1-fold (0.04 log units), on the high side; low and high end bracket the measured number.
By their numbers in this assay, from the lowest: compounds 4, 2, 1 and 3 (each within the scatter of the next).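

In this assay, methoxycarbonyl on an aromatic carbon, para to a large group, is not told apart from nitro (a 1.1-fold lower number from compound 3 to compound 4 (0.06 log units; within the scatter)), chloro (a 1.0-fold lower number from compound 2 to compound 4 (0.02 log units; within the scatter)) or methyl (a 1.1-fold lower number from compound 1 to compound 4 (0.04 log units; within the scatter)). The flat picture at this position therefore now covers four groups, and replacing nitro with this slightly larger group, which carries no nitrogen, gives no step beyond the scatter. No measurement is available that would account for this lack of separation.

From the compounds shown here alone, it remains open whether an amine, a carboxylic acid or a longer chain at this place would give a step beyond the scatter. Also open, going by these compounds, is whether a change elsewhere on the shared core would move the number at all.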